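The compounds below may be only part of what the source reports. "The series", "measured", "known", "first", "only" and "open" are said of these compounds alone.

All three measured compounds share one core and carry an amide whose carbonyl carbon bears a changing aryl group. Compound 1 `O=C(Nc1ccc(Cl)c(-c2nnc3c(Cl)cccn23)c1)c1cccnc1` has pyridin-3-yl there; in a functional assay on MCF7 cells (Homo sapiens) for antiproliferative activity, read by MTT assay, with a stated time of 72 h (a lower number here means a stronger inhibitor, a higher number a weaker inhibitor), compound 1 gives > 100000 nM, which is a limit of the assay and not a number. Compound 2 `O=C(Nc1ccc(Cl)c(-c2nnc3c(Cl)cccn23)c1)c1ccc(C(F)(F)F)cc1F` gives 62800 nM. Compound 3 `CS(=O)(=O)c1ccc(C(=O)Nc2ccc(Cl)c(-c3nnc4c(Cl)cccn34)c2)cc1` gives 94200 nM; of the two numbers shown this is the larger, but its gap to compound 2 falls within the scatter, so the two cannot be told apart. The step of an at least 1.0-fold lower number from compound 1 to compound 3 (0.02 log units; that floor lies within the scatter) is only a floor, because compound 1 sits at the limit of > 100000 nM in this assay, at which 1 of the 3 values shown sits, and it tells little. Compound 4 `O=C(Nc1ccc(Cl)c(-c2nnc3c(Cl)cccn23)c1)c1ccccc1Cl` is not yet measured and differs from compound 3 by 2-chlorophenyl in place of 4-(methylsulfonyl)phenyl on a carbonyl carbon. Among the compounds with values here, no measured step swaps one substituted phenyl for another; the only guide is that compound 2 and compound 3, with different phenyl substituents, lie within the scatter of each other. A step of a 1.6-fold lower number from compound 3 to compound 4 (0.20 log units; within the scatter) is therefore expected, meaning little real change. Compound 4 is estimated at 60000 nM, between 25000 nM and 150000 nM.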

Compound 4, half-maximal inhibitory concentration: 92200 nM
Beside the measured number, compound 4's estimate is 1.5-fold (0.19 log units) below it; low and high end bracket the measured number.
By their numbers in this assay, from the lowest: compounds 2, 4 and 3 (each within the scatter of the next). At a limit, above all of these: compound 1.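

In this assay, within the data shown here, there is a 1.0-fold lower number from compound 3 to compound 4 (0.01 log units; within the scatter); this is the only readable swap of one substituted phenyl for another on this carbonyl carbon, and it lies within the scatter. The two compounds cannot be told apart, even though 4-(methylsulfonyl)phenyl has 10 heavy atoms and 2 hydrogen-bond acceptors, while 2-chlorophenyl has 7 heavy atoms and 0 hydrogen-bond acceptors. The step of an at least 1.0-fold lower number from compound 1 to compound 4 (0.03 log units; that floor lies within the scatter) is only a floor and tells little. Compound 1 holds a limit and not a number: the limit of > 100000 nM in this assay, at which 1 of the 4 values shown sits.

Every group shown on this carbonyl carbon is a six-membered aromatic ring, so the effect of replacing that ring with something of another kind remains open. Going by these compounds, whether an amine, a carboxylic acid or a longer alkyl chain at this place would give a number clearly different from these also remains unknown.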